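Furan-2-yl for iodo on a ribosylated fused core

The source may hold more compounds than are shown below. What is called first, only, known or untested is meant among the compounds shown, and "the series" means these compounds.

The compounds are measured in a functional assay on A549 cells (Homo sapiens), read by MTT assay, with a stated time of 72 h; on this read-out lower numbers stand for stronger inhibition and higher numbers for weaker inhibition. Compound 1, `CSc1ncnc2c1c(-c1ccccc1)cn2[C@@H]1O[C@H](CO)[C@@H](O)[C@H]1O`, reaches only the limit of the assay: in this assay compound 1 gives > 20000 nM, which marks the limit of > 20000 nM in this assay, at which 1 of the 2 values shown sits, rather than a number. For the measured compounds named here, compound 2, `Cc1nc(N)c2c(I)cn([C@@H]3O[C@H](CO)[C@@H](O)[C@H]3O)c2n1`, is the one compound for which a number exists: in this assay compound 2 gives 12100 nM, the only actual number among the two values shown.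

Compound 3, `Cc1nc(N)c2c(-c3ccco3)cn([C@@H]3O[C@H](CO)[C@@H](O)[C@H]3O)c2n1`, has not yet been measured in this assay. It differs from compound 2 in one place: furan-2-yl in place of iodo on an aromatic carbon. Going by the values given here, no pair of measured compounds differing in one place is available, so the size of this kind of step is unknown from these data alone.

Given that compound 2 gives 12100 nM, compound 3 is expected to lie near it, with the step of a 1.5-fold lower number from compound 2 to compound 3 (0.18 log units; within the scatter) estimated to stay within the usual scatter or to lean only slightly toward stronger inhibition. The estimate for compound 3 is therefore 8000 nM, in a range from 2000 nM to 30000 nM, with a fair chance that only a limit is reported.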

Compound 3, half-maximal inhibitory concentration: > 20000 nM
Compound 3: a limit, no number (the forecaster's own chance of this, stated with the estimate: 35%); middle value at least 2.5-fold (0.39 log units) from the limit.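

In this assay, for the compounds shown here, replacing iodo with furan-2-yl on this aromatic carbon gives the first step that can be read at this position, and it is an at least 1.6-fold higher number from compound 2 to compound 3 (0.21 log units; that floor lies within the scatter). Compound 3 gives > 20000 nM, which is a limit of the assay and not a number, so the step has only a floor, and that floor does not separate the two compounds beyond the usual scatter. The larger group with its five-membered aromatic ring therefore gives no sign of stronger inhibition at this place, and the one number at this position still belongs to compound 2, while the other compounds now rest at the assay's ceiling: the limit of > 20000 nM in this assay, at which 2 of the 3 values shown sit.

From the compounds shown here alone, how far compound 3 lies past that limit remains open, and with it the true size of the step and whether the change weakens inhibition at all. Also open, going by these compounds, is whether a chloro group, a methyl group or an aminomethyl group on the same aromatic carbon would move the read-out away from the value of compound 2, in either direction.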